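Two Quaternary Tails on Two Differently Joined Cores

The source may report more compounds than this note shows. Statements on the series, on what has been measured and on what is new or still open speak of the compounds shown alone.

Compound 1 `Cc1cc(OCCCCCCC[n+]2ccccc2)cc(-n2cc(C(=O)Nc3cc(F)cc(F)c3)c(=O)c3ccc(N(C)C)nc32)c1` and compound 2 `Cc1ccc(-n2cc(C(=O)Nc3cc(F)cc(F)c3)c(=O)c3ccc(N(C)C)nc32)cc1OCCCCCCC[n+]1ccccc1` are built from the same atoms, joined differently, and the difference between the two cores is not broken down here. In an assay on LX2 cells for inhibition of COL1A1 promoter (Homo sapiens), read by a luciferase reporter, with a stated time of 24 h, tested at 20 uM (on this read-out higher numbers stand for a stronger effect at the one concentration tested and lower numbers for a weaker effect), compound 1 gives 7.7%, while compound 2 gives 39.7%, the highest of the three numbers and beyond the scatter from the other two. Compound 3 `Cc1cc(OCCCCCCC[N+]2(C)CCN(C)CC2)cc(-n2cc(C(=O)Nc3cc(F)cc(F)c3)c(=O)c3ccc(N(C)C)nc32)c1` carries a group of 8 heavy atoms (6 carbon, 2 nitrogen; one six-membered non-aromatic ring with 2 hetero atoms) in place of a group of 6 heavy atoms (5 carbon, 1 nitrogen; one six-membered aromatic ring with 1 hetero atom), on a saturated chain carbon, seven bonds along the chain from an oxygen on an aromatic ring. In this assay compound 3 gives 2.8%, and the step of a number 4.9 percentage points lower from compound 1 to compound 3 (within the scatter) shows that this exchange of tail barely moves the read-out on the core of compound 1.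

Compound 4 `Cc1ccc(-n2cc(C(=O)Nc3cc(F)cc(F)c3)c(=O)c3ccc(N(C)C)nc32)cc1OCCCCCCC[N+]1(C)CCN(C)CC1`, still to be measured, carries the same change on the core of compound 2: a group of 8 heavy atoms (6 carbon, 2 nitrogen; one six-membered non-aromatic ring with 2 hetero atoms) in place of a group of 6 heavy atoms (5 carbon, 1 nitrogen; one six-membered aromatic ring with 1 hetero atom), on a saturated chain carbon, seven bonds along the chain from an oxygen on an aromatic ring. Because the step of a number 4.9 percentage points lower from compound 1 to compound 3 (within the scatter) lay within the scatter, the tail change is expected to leave compound 4 close to compound 2, with an estimated step of a number 4.7 percentage points lower from compound 2 to compound 4 (within the scatter). Among the compounds with values here, for compound 4 in this assay the estimate is 35%, expected to fall between 18% and 50%, resting on the single pairing of compound 1 with compound 3.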

Compound 4, a percentage reported as inhibition, at one concentration (the size of the read-out at that concentration, not a potency): 10.4%
Estimate against measurement, compound 4: 24.6 percentage points above; measured number outside the range, below it.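

In this assay, the exchange of the tail on the core of compound 2 gives a clear drop, a number 29.3 percentage points lower from compound 2 to compound 4 (beyond the scatter), and the pyridinium-type group with one hetero atom therefore cannot be swapped for the non-aromatic ring with 2 hetero atoms without consequence on this core. The same change does not carry over from one core to the other at the same size: the same change on two cores in this assay, a number 4.9 percentage points lower (within the scatter) from compound 1 to compound 3 and a number 29.3 percentage points lower (beyond the scatter) from compound 2 to compound 4, 24.4 percentage points apart, beyond the scatter of two such steps Two pairs read at one concentration give no potency, no reason why the two cores respond differently, and no guide to how the change would behave on a third core.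

The compounds shown leave open how a tail ending in a simple trimethylammonium group or a neutral piperidine would read on either core. They also leave open whether a shorter or a longer chain would keep the two cores as far apart as they stand here.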